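Thiazole for Pyrimidinyloxy: an Expected Shift in Cytotoxicity

This account rests on a few compounds, and the source may have more. Where it says the series, first, only, none or still open, it means among the compounds named here.

In a toxicity assay on HepG2 2.2.15 cells (Homo sapiens) for cytotoxicity, read by CellTiter-Glo (a higher number here means that more compound is tolerated, a lower number that less compound is tolerated), compound 3 `O=C1CC(Oc2ncccn2)CN1c1cnn2c1CN(C(=O)Nc1cc(F)c(F)c(F)c1)C(C1CC1)C2` reports only a limit, > 200000 nM. Compound 1 `O=C1CC(c2cnco2)CN1c1cnn2c1CN(C(=O)Nc1cc(F)c(F)c(F)c1)C(C1CC1)C2` gives 139000 nM in this assay, and compound 2 `O=C1CC(c2cnc(C(F)(F)F)s2)CN1c1cnn2c1CN(C(=O)Nc1cc(F)c(F)c(F)c1)C(C1CC1)C2` gives 38500 nM. Compound 3 thus stands at the boundary described by the limit of > 200000 nM in this assay, at which 1 of the 3 values shown sits, the only one of the three to do so. Compound 4 `Cc1cnc(C2CC(=O)N(c3cnn4c3CN(C(=O)Nc3cc(F)c(F)c(F)c3)C(C3CC3)C4)C2)s1` has not yet been measured. It differs from compound 3 by 5-methyl-1,3-thiazol-2-yl in place of (pyrimidin-2-yl)oxy on a saturated ring carbon. Among the measured compounds shown here, two measured steps bear on this change: an at least 5.1-fold higher number from compound 2 to compound 3 (0.71 log units; beyond the scatter) and an at least 1.4-fold higher number from compound 1 to compound 3 (0.15 log units; that floor lies within the scatter) both place the (pyrimidin-2-yl)oxy group at a higher number than a five-membered aromatic ring on the same saturated ring carbon, and a 3.6-fold lower number from compound 1 to compound 2 (0.56 log units; beyond the scatter) shows that 2-(trifluoromethyl)-1,3-thiazol-5-yl sits lower than 1,3-oxazol-5-yl. Since compound 4 carries a 5-methyl-1,3-thiazol-2-yl group, a modest downward step in this assay is expected, though the methyl is not the trifluoromethyl of compound 2. Compound 4 is accordingly expected to give 70000 nM, in a range from 25000 nM to 200000 nM. The expected step is an at least 2.8-fold lower number from compound 3 to compound 4 (0.45 log units; beyond the scatter).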

Compound 4, half-maximal cytotoxic concentration: 96200 nM
The estimate for compound 4 lay 1.4-fold (0.14 log units) below the measured number; measured number inside the range.
By their numbers in this assay, from the lowest: compound 2; then compounds 4 and 1 (each within the scatter of the next). At a limit, above all of these: compound 3.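

The new result shows that a 5-methyl-1,3-thiazol-2-yl group on this saturated ring carbon also stands apart from the (pyrimidin-2-yl)oxy group in this assay, with an at least 2.0-fold lower number from compound 3 to compound 4 (0.31 log units; beyond the scatter). The two thiazole groups are not interchangeable, with a 2.5-fold higher number from compound 2 to compound 4 (0.40 log units; beyond the scatter), whereas a 1.4-fold lower number from compound 1 to compound 4 (0.16 log units; within the scatter) leaves the 5-methyl-1,3-thiazol-2-yl and 1,3-oxazol-5-yl groups indistinguishable. Compound 3 remains alone at a limit, which is not a number: the limit of > 200000 nM in this assay, at which 1 of the 4 values shown sits.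

The compounds shown leave open whether the gap between the two thiazole groups follows from methyl against trifluoromethyl or from the 2-yl against the 5-yl attachment, as both change together in this pair. They also leave open how an amine or a carboxylic acid on this saturated ring carbon would read in this assay.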